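Swapping a saturated ring for a methylphenyl on the core

The source may hold more compounds than are shown below. What is called first, only, known or untested is meant among the compounds shown, and "the series" means these compounds.

Measured compounds:
compound 1 `Cc1cc(C)c(S(=O)(=O)N2CCC(C3OCC(C)CO3)CC2)c(C)c1` in an ADME assay on HCT-116 cells (Homo sapiens) for cytotoxicity, read by CellTiter-Glo, with a stated time of 72 h; on this read-out higher numbers stand for weaker inhibition and lower numbers for stronger inhibition: > 5000 nM
compound 2 `CC1CCN(C2CCN(S(=O)(=O)c3ccc(C(C)C)cc3)CC2)CC1`: > 5000 nM

Compound 1 reports only a limit of the assay, > 5000 nM. Compound 2 likewise reports only a limit, > 5000 nM. Compound 1 therefore stands nowhere distinct: both values shown sit at the limit of > 5000 nM in this assay, at which 2 of the 2 values shown sit. Compound 3 `Cc1ccc(C2CCN(S(=O)(=O)c3c(C)cc(C)cc3C)CC2)cc1` is not yet measured. It differs from compound 1 by a group of 7 heavy atoms (7 carbon; one six-membered aromatic ring of carbon only) in place of a group of 7 heavy atoms (5 carbon, 2 oxygen; one six-membered non-aromatic ring with 2 hetero atoms), on a saturated ring carbon. Among the compounds with values here, with no measured step to guide it, the change is expected to move the value by no more than the scatter, so the step that the limit leaves unreadable from compound 1 to compound 3 is estimated as small. Compound 3 is expected to give about 8000 nM, within 3000 nM to 30000 nM.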

Compound 3, half-maximal inhibitory concentration: > 5000 nM
Compound 3: no number, only a limit; the forecaster's own chance of this, stated with the estimate: 80%; the middle value does not contradict the limit.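

Within the data shown here, no step from compound 1 to compound 3 can be read in this assay because both give only a limit: the limit of > 5000 nM in this assay, at which 3 of the 3 values shown sit.

The compounds shown leave open how strongly any of them inhibits these cells, and whether the 4-methylphenyl change moves the value at all.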